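A few compounds are considered here, and "the series" means these few. Any claim that something is new, unique, unknown or untested is made for them only; others in the source may bear on it.

Working notes on the series. Compound 1 `CN(c1cccc2c1CN(c1nc(Nc3cc(C(F)(F)F)cc(C(F)(F)F)c3)ncc1C(F)(F)F)C2)S(C)(=O)=O` gives 10300 nM in a functional assay on HepG2 cells (Homo sapiens) for antiproliferative activity, read by spectrophotometry, with a stated time of 2 days; on this read-out higher numbers stand for weaker inhibition of growth and lower numbers for stronger inhibition of growth. Compound 3 `COc1cc(Nc2ncc(C(F)(F)F)c(N3Cc4cccc(N(C)S(C)(=O)=O)c4C3)n2)cc(OC)c1` gives 1800 nM in this assay. Compound 2 `COc1ccc(C(F)(F)F)cc1Nc1ncc(C(F)(F)F)c(N2Cc3cccc(N(C)S(C)(=O)=O)c3C2)n1` gives only a limit of the assay, > 30000 nM in this assay. That is the limit (the limit of > 30000 nM in this assay, at which 1 of the 3 values shown sits); compound 2 therefore stands at the weak end of the numbers shown, with no number of its own.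

Compound 4 `COc1cc(Nc2ncc(C(F)(F)F)c(N3Cc4cccc(N(C)S(C)(=O)=O)c4C3)n2)cc(C(F)(F)F)c1` is not yet measured. Its change from compound 2 is 3-methoxy-5-(trifluoromethyl)phenyl in place of 2-methoxy-5-(trifluoromethyl)phenyl on a nitrogen on an aromatic ring. Within the data shown here, the one measured step that bears on this is an at least 16-fold lower number from compound 2 to compound 3 (1.22 log units; beyond the scatter), a large move beyond the scatter, in which the 3,5-dimethoxyphenyl replaced the 2-methoxy-5-(trifluoromethyl)phenyl. Compound 4 keeps one methoxy and one trifluoromethyl but carries them as 3-methoxy-5-(trifluoromethyl)phenyl, so a sizeable move toward stronger growth inhibition in this assay is expected, though compound 1, at 10300 nM, cautions that a trifluoromethyl on this ring need not reach the number of compound 3. Compound 4 is expected to give 4500 nM, with a range of 1500 nM to 15000 nM. This estimate means a step of an at least 6.6-fold lower number from compound 2 to compound 4 (0.82 log units; beyond the scatter), beyond the scatter.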

Compound 4, concentration for 50% growth inhibition: 22100 nM
The estimate for compound 4 lay 4.9-fold (0.69 log units) below the measured number; the measured number lies above the stated range.
By their numbers in this assay, from the lowest: compound 3; then compound 1; then compound 4. At a limit, above all of these: compound 2.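

With the limit of compound 2 as the only reference, the position of the methoxy on this ring is not shown to matter in this assay: an at least 1.3-fold lower number from compound 2 to compound 4 (0.13 log units; that floor lies within the scatter), and that floor says only that a gain, if any, is not established. Compound 2 remains a limit of the assay, not a number. The new information lies in the exchange of trifluoromethyl and methoxy, which has no single direction here: a 12-fold higher number from compound 3 to compound 4 (1.09 log units; beyond the scatter) for trifluoromethyl in place of methoxy on an aromatic carbon, yet a 2.1-fold higher number from compound 1 to compound 4 (0.33 log units; beyond the scatter) for methoxy in place of trifluoromethyl on an aromatic carbon, so the mixed ring of compound 4 sits above both matched rings.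

Nothing shown accounts for these moves. As far as these compounds go, whether a nitrile or an amine in place of the methoxy of compound 4 would keep this trend remains open.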